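This account rests on a few compounds, and the source may have more. Where it says the series, first, only, none or still open, it means among the compounds named here.

Compound 1 `CCCCNc1ccnc2cc(Cl)ccc12` was tested in a functional assay on 184B5 cells (Homo sapiens) for cytotoxicity, read by sulforhodamine B assay, with a stated time of 48 h, in the presence of a further agent that is not named here; on this read-out lower numbers stand for stronger inhibition of growth and higher numbers for weaker inhibition of growth. In this assay compound 1 gives > 20000 nM, which is a limit of the assay rather than a measured number. Compound 2 `CCCCNc1ccnc2cc(F)ccc12` differs from it by fluoro in place of chloro on an aromatic carbon, and in this assay compound 2 gives 12400 nM. The step of an at least 1.6-fold lower number from compound 1 to compound 2 (0.20 log units; that floor lies within the scatter) rests on (the limit of > 20000 nM in this assay, at which 1 of the 2 values shown sits), and its floor lies within the scatter, so it shows no clear change. Compound 3 `CN(C)CCNc1ccnc2cc(Cl)ccc12` has not yet been measured; it differs from compound 1 by dimethylamino in place of ethyl on a saturated chain carbon, two bonds along the chain from a nitrogen on an aromatic ring. Among the measured compounds shown here, no measured step touches this part of the molecule, and the only measured step, that from compound 1 to compound 2, stays within the scatter. The analyst therefore expects no step beyond the scatter, namely an at least 1.3-fold lower number from compound 1 to compound 3 (0.12 log units; that floor lies within the scatter). Her estimate for compound 3 in this assay is 15000 nM, with a range from 5000 nM to 45000 nM.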

Compound 3, concentration for 50% growth inhibition: > 20000 nM
Compound 3: no number, only a limit; the forecaster's own chance of this, stated with the estimate: 45%; at least 1.3-fold (0.12 log units) between middle value and limit.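

In this assay compound 3 gives > 20000 nM, which is a limit of the assay and not a number. Among the compounds shown here, no step between compound 1 and compound 3 can be read, because both compounds stand at that same limit: the limit of > 20000 nM in this assay, at which 2 of the 3 values shown sit. The compounds shown leave open whether dimethylamino in place of ethyl changes the number in this assay at all.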